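The compounds below may be only part of what the source reports. "The series", "measured", "known", "first", "only" and "open" are said of these compounds alone.

Measured compounds:
- compound 1, `N#CC1=C(N)Oc2c(N)cc3nc4ccccc4nc3c2C12C(=O)N(Cc1cnnn1-c1ccccc1Cl)c1ccccc12`, gives 34400 nM in a functional assay on MCF7 cells (Homo sapiens) for antiproliferative activity, read by MTT assay, with a stated time of 48 h; on this read-out lower numbers stand for stronger inhibition and higher numbers for weaker inhibition
- compound 2, `N#CC1=C(N)Oc2c(N)cc3nc4ccccc4nc3c2C12C(=O)N(Cc1cnnn1-c1cccc(C(F)(F)F)c1)c1ccccc12`, gives 31600 nM
- compound 3, `COc1ccccc1-n1nncc1CN1C(=O)C2(C(C#N)=C(N)Oc3c(N)cc4nc5ccccc5nc4c32)c2ccccc21`, gives 28900 nM

All three share one core and differ only in the aryl group hanging on the nitrogen of the five-membered ring with three nitrogens. Compound 3 carries the lowest number of the three, yet its gaps to the others are small: a 1.2-fold lower number from compound 1 to compound 3 (0.08 log units; within the scatter) and a 1.1-fold lower number from compound 2 to compound 3 (0.04 log units; within the scatter), and likewise a 1.1-fold lower number from compound 1 to compound 2 (0.04 log units; within the scatter). None of these steps rises above the scatter, so the three compounds cannot be placed in any order on this read-out.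

Compound 4, `CCOc1ccc(-n2nncc2CN2C(=O)C3(C(C#N)=C(N)Oc4c(N)cc5nc6ccccc6nc5c43)c3ccccc32)cc1`, is the next member of this series. The change from compound 3 is 4-ethoxyphenyl in place of 2-methoxyphenyl on an aromatic nitrogen. It is the same kind of swap that the three measured steps cover: one aryl group on that nitrogen traded for another. Since each of those trades left the number essentially where it was, no movement beyond the scatter is expected here either, in either direction. Compound 4 is therefore expected to give about 30000 nM, within the range 15000 nM to 60000 nM, which means an expected step of a 1.0-fold higher number from compound 3 to compound 4 (0.02 log units; within the scatter).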

Compound 4, half-maximal inhibitory concentration: 26800 nM
For compound 4 the middle estimate is 1.1-fold (0.05 log units) above the measured one; the range from low to high includes it.
By their numbers in this assay, from the lowest: compounds 4, 3, 2 and 1 (each within the scatter of the next).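

In this assay, 4-ethoxyphenyl in place of 2-methoxyphenyl gives a 1.1-fold lower number from compound 3 to compound 4 (0.03 log units; within the scatter), while the comparisons with the other two aryl groups give a 1.2-fold lower number from compound 2 to compound 4 (0.07 log units; within the scatter) and a 1.3-fold lower number from compound 1 to compound 4 (0.11 log units; within the scatter). Compound 4 adds an ethoxy chain to the groups tried on this aromatic nitrogen, and its name carries a different ring number from those of the three earlier aryl groups, yet none of these steps rises above the scatter, so the four compounds cannot be put in order on this read-out. Nothing given here offers a reason why the numbers stay so close together.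

The step from 2-methoxyphenyl to 4-ethoxyphenyl changes both the chain and its place on the ring. 4-methoxyphenyl and 2-ethoxyphenyl would be needed to tell those two changes apart. On these data alone, all four compounds also keep a phenyl ring on this nitrogen, so it remains open how the read-out would respond to a phenyl ring bearing an amine or a carboxylic acid, or to a plain butyl chain in place of the ring.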